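A few compounds are considered here, and "the series" means these few. Any claim that something is new, unique, unknown or untested is made for them only; others in the source may bear on it.

Compound 3 `CCCc1ccccc1N1CCN(CCCNc2ncccc2C(=O)N(C)C)CC1` has the lowest number among the three measured compounds in a functional assay for antagonist activity at Alpha-1A adrenergic receptor (Oryctolagus cuniculus) (a lower number here means tighter binding, a higher number weaker binding), giving 0.2 nM. Compound 1 `CCOc1ccccc1N1CCN(CCCNc2ncccc2C(=O)N(C)C)CC1` gives 0.501 nM in this assay, and compound 2 `Cc1cnccc1N1CCN(CCCNc2ncccc2C(=O)N(C)C)CC1` gives 200 nM. The step of a 2.5-fold lower number from compound 1 to compound 3 (0.40 log units; beyond the scatter) was modest, whereas a 400-fold higher number from compound 1 to compound 2 (2.60 log units; beyond the scatter) and a 1000-fold lower number from compound 2 to compound 3 (3.00 log units; beyond the scatter) were large.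

Compound 4 `COc1cc(C)ccc1N1CCN(CCCNc2ncccc2C(=O)N(C)C)CC1` is compound 3 with one change: 2-methoxy-4-methylphenyl in place of 2-propylphenyl on an amine nitrogen in a ring. The change that bears most on this is the modest one between compound 1 and compound 3, since compound 4 resembles compound 1 in carrying an alkoxy group on the aromatic ring, with an added methyl. Compound 2 shows that replacing the aromatic ring wholesale gives a large shift, but compound 4 keeps the carbon-only ring.

Compound 4 is therefore expected to give a slightly higher number than compound 3, close to compound 1, with the step of a 2.5-fold higher number from compound 3 to compound 4 (0.40 log units; beyond the scatter) estimated as modest. The estimated value for compound 4 in this assay is 0.5 nM, within a range from 0.15 nM to 2 nM.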

Compound 4, dissociation constant: 0.794 nM
Compound 4: the middle estimate sits 1.6-fold (0.20 log units) below what was measured; the measured number falls inside the stated range.
By their numbers in this assay, from the lowest: compound 3; then compounds 1 and 4 (each within the scatter of the next); then compound 2.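

In this assay, the swap from 2-propylphenyl to 2-methoxy-4-methylphenyl on the ring amine nitrogen is a modest step (a 4.0-fold higher number from compound 3 to compound 4 (0.60 log units; beyond the scatter)), so a ring with two substituents, a methoxy and a methyl group, remains compatible with a low number at this place. Set against the 2-ethoxyphenyl group, the same group gives no readable difference (a 1.6-fold higher number from compound 1 to compound 4 (0.20 log units; within the scatter)), which means compound 4 and compound 1 cannot be ordered. Compared with 3-methylpyridin-4-yl, the new group again gives a large step (a 250-fold lower number from compound 2 to compound 4 (2.40 log units; beyond the scatter)), so all three carbon-only rings shown sit far from compound 2. The compounds shown leave open whether the methoxy or the methyl group accounts for the step from compound 3, and how a 2-chlorophenyl or 2-hydroxyphenyl group would behave at this place. Nothing available here gives a reason for any of these steps.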